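The compounds below may be only part of what the source reports. "The series", "measured", "known", "first", "only" and "open" are said of these compounds alone.

Compound 1 `O=C(Nc1ccc(F)cc1)c1c(NO)cc(-c2ccccc2)oc1=O` is the starting point of this account. In an ADME assay on Huh-7 cells (Homo sapiens) for cytotoxicity, read by a luciferase reporter and WST assay, with a stated time of 3 days (on this read-out higher numbers stand for lower toxicity in this test and lower numbers for higher toxicity in this test), compound 1 gives a value that is only a limit of the assay, > 20000 nM. Two related compounds are known on the same read-out. Compound 2 `CNC(=O)c1c(NO)cc(-c2ccc(Cl)cc2)oc1=O` also returns only a limit in this assay, > 20000 nM. Compound 3 `CNC(=O)c1c(NO)cc(-c2ccc(OC)cc2)oc1=O` likewise returns only a limit, > 20000 nM. Going by the values given here, the single measured step, a step that the two limits leave unreadable from compound 2 to compound 3, is methoxy in place of chloro on an aromatic carbon, and its size cannot be read. The standing of compound 1 is thus fixed only as a limit, and the same holds for the two further values, as the limit of > 20000 nM in this assay, at which 3 of the 3 values shown sit, shows.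

The change to compound 4 `O=C(NCCO)c1c(NO)cc(-c2ccccc2)oc1=O` is 2-hydroxyethyl in place of 4-fluorophenyl on an amide-type nitrogen. Among the compounds with values here, no measured step touches the amide-type nitrogen, so none bears directly on this change; the one step recorded lies on the aromatic ring and is itself unreadable. What remains is the limit of > 20000 nM in this assay, at which 3 of the 3 values shown sit, and on that basis no step beyond the scatter is expected in this assay. The step from compound 1 to compound 4 is estimated as a step that the limit leaves unreadable from compound 1 to compound 4, in no particular direction. Compound 4 is therefore expected to show 30000 nM, with a range from 15000 nM to 100000 nM, most likely again reported only as a limit of the assay.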

Compound 4, half-maximal cytotoxic concentration: > 20000 nM
Compound 4 gave a limit, no number; the forecaster's own chance of this, stated with the estimate: 85%; the middle value lies beyond the limit too.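

Compound 1 and compound 4 both return only a limit of the assay in this assay, so no step between them can be read, and the same holds for compound 2 and compound 3: the limit of > 20000 nM in this assay, at which 4 of the 4 values shown sit.

The compounds shown leave open whether 2-hydroxyethyl or 4-fluorophenyl on the amide-type nitrogen makes any difference in this assay.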